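A few compounds are considered here, and "the series" means these few. Any claim that something is new, unique, unknown or untested is made for them only; others in the source may bear on it.

Measured compounds:
- compound 1, `c1ccc(CNC(c2ccc[nH]2)c2nnc(-c3ccccc3)o2)cc1`, 198000 nM
- compound 2, `Clc1ccc(-c2nnc(C(NCc3ccccc3)c3ccc[nH]3)o2)cc1`, 54500 nM

Among the compounds with values here, in a functional assay on HT-29 cells (Homo sapiens) for cytotoxicity, read by MTT assay, with a stated time of 24 h (a higher number here means a weaker inhibitor, a lower number a stronger inhibitor), compound 1 gives the highest of the two numbers measured, and its nearest neighbour is compound 2, which gives 54500 nM; the only step known is a 3.6-fold lower number from compound 1 to compound 2 (0.56 log units; beyond the scatter), a modest step beyond the scatter that came from a chloro group placed on the phenyl ring of the shared core.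

Compound 3, `COc1ccc(CNC(c2ccc[nH]2)c2nnc(-c3ccccc3)o2)cc1`, is not yet measured. It differs from compound 1 in a single place: methoxy in place of hydrogen on an aromatic carbon. Within the data shown here, the change sits on the benzyl ring, a different ring from the one altered in the step from compound 1 to compound 2, so that step does not speak directly to it. Among the measured compounds shown here, no measured pair shows what a methoxy group does on the benzyl ring. With only a change on another ring as a guide, a step in this assay of no more than the scatter is expected from compound 1 to compound 3, in either direction, so that compound 3 is estimated at 160000 nM, within a range of 60000 nM to 420000 nM, which amounts to an expected step of a 1.2-fold lower number from compound 1 to compound 3 (0.09 log units; within the scatter).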

Compound 3, half-maximal inhibitory concentration: 286000 nM
Compound 3: the middle estimate sits 1.8-fold (0.25 log units) below what was measured; measured number inside the range.
By their numbers in this assay, from the lowest: compound 2; then compounds 1 and 3 (each within the scatter of the next).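

In this assay the benzyl ring now has a reading of its own: methoxy in place of hydrogen, para to a large group, gives a 1.4-fold higher number from compound 1 to compound 3 (0.16 log units; within the scatter) and so leaves the number of compound 1 within the scatter. Within the data shown here, this position therefore accepts the change from benzyl to 4-methoxybenzyl with no step that can be told from repeat variation, whereas the chloro group on the other ring gave a 3.6-fold lower number from compound 1 to compound 2 (0.56 log units; beyond the scatter) as the only step beyond the scatter so far. Nothing available explains the difference between these two steps, and no measurement here bears on the methoxy result.

Each ring has so far carried a single new group, so these compounds do not show whether chloro on the benzyl ring would repeat the step seen on the other ring, or whether methoxy on that other ring would match the result seen here. As far as these compounds go, it also remains open whether a group of another kind at this position, such as an amine or a carboxylic acid, would move the number beyond the scatter in either direction.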